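A few compounds are considered here, and "the series" means these few. Any claim that something is new, unique, unknown or untested is made for them only; others in the source may bear on it.

Series notes. Compound 1 `CN1C(=O)N(c2ccccc2)C2NC(=S)N(/N=C/C=C/c3ccccc3)C21` and compound 2 `CCN1C(=O)N(c2ccccc2)C2NC(=S)N(/N=C/C=C/c3ccccc3)C21` share a core and differ only by methyl in place of hydrogen on a saturated chain carbon bound to an amide-type nitrogen in a ring. In a functional assay on A549 cells (Homo sapiens) for inhibition, read by MTT assay, with a stated time of 72 h (a lower number here means a stronger inhibitor, a higher number a weaker inhibitor), compound 1 gives a value that is a limit of the assay, > 100000 nM. Compound 2 likewise gives only a limit in this assay, > 100000 nM. The size of a step that the two limits leave unreadable from compound 1 to compound 2 is therefore not readable, since the limit of > 100000 nM in this assay, at which 3 of the 3 values shown sit, holds both ends of it.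

Compound 3 `CCN1C(=O)N(CC)C2C1N=C(SC)N2/N=C/C=C/c1ccccc1[N+](=O)[O-]` carries a different core; the difference between the two cores is not broken down here. In this assay compound 3 also returns a limit, > 100000 nM. Compound 4 `CCSC1=NC2C(N(CC)C(=O)N2CC)N1/N=C/C=C/c1ccccc1[N+](=O)[O-]` is not yet measured and differs from compound 3 by methyl in place of hydrogen on a saturated chain carbon bound to a sulfur. Among the compounds with values here, this is the same kind of change as the one from compound 1 to compound 2, not the same: in the earlier pair the place is on a saturated chain carbon bound to an amide-type nitrogen in a ring, here it is on a saturated chain carbon bound to a sulfur.

Expectation. The earlier step of this kind carries no usable size, because the limit of > 100000 nM in this assay, at which 3 of the 3 values shown sit, places every measured compound at the same limit. The expected step is a number no higher from compound 3 to compound 4 (the limit leaves the size open), with nothing in the measured set pointing to a move off the limit. For compound 4 the value expected in this assay is 100000 nM, most probably reported again only as a limit. The expected range for compound 4 runs from 30000 nM to 300000 nM.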

Compound 4, half-maximal inhibitory concentration: > 100000 nM
Compound 4 was reported as a limit; the forecaster's own chance of this, stated with the estimate: 85%; the middle value sits exactly at the limit.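

In this assay compound 4 gives > 100000 nM, which is a limit of the assay. No size can be read for the step between compound 3 and compound 4, because both sit at the same limit: the limit of > 100000 nM in this assay, at which 4 of the 4 values shown sit.

The compounds shown leave open whether methylsulfanyl to ethylsulfanyl, or methyl in place of hydrogen in the earlier pair, changes inhibition in this assay at all.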